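This account rests on a few compounds, and the source may have more. Where it says the series, first, only, none or still open, it means among the compounds named here.

Measured compounds in a functional assay on the whole organism (plasma, strain Wistar) with Rattus norvegicus as the target, with a stated time of 15 days, at a dose of 30 mg/kg by the oral route; on this read-out higher numbers stand for a stronger effect at the one dose given and lower numbers for a weaker effect:
compound 1 `Cc1nc(COc2ccc(/C=C3\SC(=O)NC3=O)cc2)cs1` gives 14.7%
compound 2 `O=C1NC(=O)/C(=C/c2ccc(OCc3csc(-c4ccccc4)n3)cc2)S1` gives 22.6%
compound 3 `O=C1NC(=O)/C(=C/c2ccc(OCCSc3nnc(-c4ccccc4)[nH]3)cc2)S1` gives 14.7%

Compound 3 stands level with compound 1 at the digits printed, and the two together are the lowest of the three numbers. Its nearest neighbour is compound 1, with no change at the digits printed, within the scatter; its furthest is compound 2, whose number lies higher, also within the scatter. Going by the values given here, no step among the three therefore reaches beyond the scatter.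

Compound 4 `O=C1NC(=O)/C(=C/c2ccc(OCCSc3nnc(Cc4ccccc4)[nH]3)cc2)S1` is not yet measured. It differs from compound 3 by one change: benzyl in place of phenyl on an aromatic carbon.

Among the compounds with values here, the only measured step, a number 7.9 percentage points higher from compound 1 to compound 2 (within the scatter), concerns phenyl in place of methyl on an aromatic carbon of a different five-membered ring, and it stayed within the scatter. Within the data shown here, no measured step covers benzyl in place of phenyl, so the single step at hand gives only weak guidance and points to a small effect at most. The expectation for this assay is therefore no step beyond the scatter, in either direction.

The estimated step is a number 0.3 percentage points higher from compound 3 to compound 4 (within the scatter). Compound 4 is expected to give 15%, with a range from 5% to 28%.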

Compound 4, a percentage reported as activity, at one dose (the size of the read-out at that dose, not a potency): 28.5%
The estimate for compound 4 lay 13.5 percentage points below the measured number; measured number outside the range, above it.
By their numbers in this assay, from the lowest: compounds 1, 3, 2 and 4 (each within the scatter of the next, the first and the last beyond it).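

In this assay, benzyl in place of phenyl on an aromatic carbon of the five-membered aromatic ring with 3 nitrogen gives a number 13.8 percentage points higher from compound 3 to compound 4 (beyond the scatter), the only step among these compounds that lies beyond the scatter. The earlier step, a number 7.9 percentage points higher from compound 1 to compound 2 (within the scatter), concerned a different ring and a different exchange, so it gave no reading of this position; the present pair shows that the read-out responds to the group placed here. The exchange is small by the counts, going from 6 heavy atoms to 7 heavy atoms, with the six-membered aromatic ring of carbon kept and no hydrogen-bond donors or acceptors on either group, and nothing available on this result explains the rise.

A single pair cannot show whether the gain continues with a longer chain such as 2-phenylethyl or depends on the aromatic ring at all, which a plain cyclohexylmethyl group would test. From the compounds shown here alone, how a carboxylic acid or an amine on the benzyl ring would behave at this position also remains open.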